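Carboxyphenoxy replacement in a thiazepinone-free series: expected potency

This account rests on a few compounds, and the source may have more. Where it says the series, first, only, none or still open, it means among the compounds named here.

Measured so far:
compound 1, `CCOc1cccc(-c2ccc([C@H]3S[C@@H](C)C(=O)Nc4c3c(C)nn4-c3ccccc3C)cc2)c1`, 3500 nM
compound 2, `COc1cc([C@H]2S[C@@H](C)C(=O)Nc3c2c(C)nn3-c2ccccc2C)ccc1Oc1ccccc1`, 1900 nM

Both compounds share the same core and were read in an assay on isolated protein for agonist activity at Bile acid receptor (Homo sapiens), read by AlphaScreen, with a stated time of 30 min; a higher number here means that more compound is needed for the effect, a lower number that less compound is needed. Compound 1 gives 3500 nM and stands at the highest of the two numbers; compound 2, with 1900 nM, lies within the usual scatter of it, so no order between the two can be claimed.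

Compound 3, `Cc1ccccc1-n1nc(C)c2c1NC(=O)[C@H](C)S[C@@H]2c1ccc(Oc2ccccc2C(=O)O)cc1`, is not yet measured. Relative to compound 1 the change is 2-carboxyphenoxy in place of 3-ethoxyphenyl on an aromatic carbon. Among the compounds with values here, no pair among the measured compounds differs in one place, so no measured step guides this one. The expectation is a modest step from compound 1 to compound 3 of a 1.4-fold lower number from compound 1 to compound 3 (0.15 log units; within the scatter), toward a lower number but possibly not beyond the scatter. For compound 3 the estimate in this assay is 2500 nM, with a range from 700 nM to 9000 nM.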

Compound 3, half-maximal effective concentration: "not active" (no number reported)
The entry for compound 3 holds no number; no gap can be computed for the estimate.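

Within the data shown here, compound 3 is reported as "not active", with no number, so no step from compound 1 to compound 3 can be read. The compounds shown leave open whether the 2-carboxyphenoxy group, or only its attachment through oxygen, accounts for this result. No available evidence bears on it.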